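A few compounds are considered here, and "the series" means these few. Any claim that something is new, unique, unknown or untested is made for them only; others in the source may bear on it.

Measured in an in vitro ADME assay on microsomes from liver (Simiiformes); a lower number here means that the compound disappears faster, a higher number that the compound lasts longer:
- compound 1 `CCc1cc(CCCOc2c(C)cc(-c3noc(C)n3)cc2C)on1`: 0.183 h
- compound 2 `CCc1cc(CCCOc2c(C)cc(-c3noc(C(F)(F)F)n3)cc2C)on1`: > 2.5 h (a limit)

The value of compound 2, > 2.5 h, is a limit of the assay and not a number.

Compound 3 `CC(=O)c1ccc(CCCOc2c(C)cc(-c3noc(C(F)(F)F)n3)cc2C)o1` carries 5-acetylfuran-2-yl in place of 3-ethyl-1,2-oxazol-5-yl on a saturated chain carbon, three bonds along the chain from an oxygen on an aromatic ring. Among the measured compounds shown here, the one measured step, an at least 13-fold higher number from compound 1 to compound 2 (1.13 log units; beyond the scatter), is large but concerns trifluoromethyl in place of methyl, elsewhere in the molecule, so it sets no size for this change. A moderate drop in this assay is expected with low confidence, and the expected step is an at least 1.6-fold lower number from compound 2 to compound 3 (0.22 log units; that floor lies within the scatter). For compound 3 the estimate is 1.5 h, with an expected range of 0.4 h to 4 h.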

Compound 3, half-life: 1.05 h
Compound 3: middle estimate off by 1.4-fold (0.15 log units), on the high side; low and high end bracket the measured number.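

In this assay, the half-life also responds to the group on the saturated chain carbon, three bonds along the chain from an oxygen on an aromatic ring, not only to trifluoromethyl in place of methyl: 5-acetylfuran-2-yl in place of 3-ethyl-1,2-oxazol-5-yl gives an at least 2.3-fold lower number from compound 2 to compound 3 (0.37 log units; beyond the scatter). Compound 2 stands at > 2.5 h, which is a limit of the assay and not a number. The step is therefore only a floor, and its full size stays unknown: the limit of > 2.5 h in this assay, at which 1 of the 3 values shown sits.

On these data alone, whether the acetyl group or the furan ring carries the step stays open. Also open, as far as these compounds go, is how a 3-ethyl-1,2-oxazol-5-yl replacement bearing a carboxylic acid or an amine would behave at this position.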